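One Methoxy Less: What to Expect of Compound 4

The source may hold more compounds than are shown below. What is called first, only, known or untested is meant among the compounds shown, and "the series" means these compounds.

This account concerns a small set of related compounds tested in a functional assay on COLO 205 cells (Homo sapiens) for inhibition, read by sulforhodamine B assay, with a stated time of 48 h, tested at 50 uM; a higher number here means more inhibition of growth at the concentration tested, a lower number less inhibition of growth. Compound 1 `COc1cc(/C=C/C(=O)/C=C/c2ccccc2)ccc1OCc1cn(CCCCOc2cc(=O)oc3ccccc23)nn1` gives 31%. Compound 3 `COc1ccccc1/C=C/C(=O)/C=C/c1ccc(OCc2cn(CCCCOc3cc(=O)oc4ccccc34)nn2)c(OC)c1` gives 47%. Compound 2 `COc1cc(/C=C/C(=O)/C=C/c2cc(OC)c(OC)c(OC)c2)ccc1OCc1cn(CCOc2cc(=O)oc3ccccc23)nn1` gives 86%, the highest of the three, its steps to compound 3 and to compound 1 both lying beyond the scatter. The difference between the core of compound 2 and the core of compound 3 is not broken down here.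

One structural change appears twice among these compounds. From compound 3 to compound 1 it reads (hydrogen in place of methoxy on an aromatic carbon), and in this assay it made a number 16 percentage points lower from compound 3 to compound 1 (beyond the scatter). The unmeasured compound 4 `COc1ccc(/C=C/C(=O)/C=C/c2ccc(OCc3cn(CCOc4cc(=O)oc5ccccc45)nn3)c(OC)c2)cc1OC` differs from compound 2 by hydrogen in place of methoxy on an aromatic carbon. The surroundings are not the same: in the measured pair the carbon is ortho to a large group, whereas in compound 4 it is ortho to a methoxy group, meta to a large group and meta to a methoxy group, so this is the same kind of change rather than the same change.

In this assay the expected step is a number 18 percentage points lower from compound 2 to compound 4 (beyond the scatter), and this expectation rests on a number 16 percentage points lower from compound 3 to compound 1 (beyond the scatter) together with the high starting value of compound 2, 86%. Compound 4 is estimated at 68%, with a range from 50% to 85%.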

Compound 4, percent growth inhibition at one concentration: 80%
For compound 4 the middle estimate is 12 percentage points below the measured one, within the range that was stated.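

In this assay, the exchange of 3,4,5-trimethoxyphenyl for 3,4-dimethoxyphenyl gives a number 6 percentage points lower from compound 2 to compound 4 (within the scatter), so the loss of this methoxy group leaves no change that can be distinguished from repeat-measurement noise. Set beside the earlier case of hydrogen in place of methoxy on an aromatic carbon, the new step cannot be told apart from it: the same change on two cores in this assay, a number 16 percentage points lower (beyond the scatter) from compound 3 to compound 1 and a number 6 percentage points lower (within the scatter) from compound 2 to compound 4, 10 percentage points apart, within the scatter of two such steps This shows that, across these two pairs, the change can be carried from one core to the other without a detectable difference in its step, but it does not show that the two steps are equal in size or that the change always lowers growth inhibition, as only the earlier step lies beyond the scatter, and the two pairs differ both in their cores and in the surroundings of the changed carbon.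

The compounds shown leave open what a hydroxyl group, a chlorine atom or an amine would do at the position of the lost methoxy group, since only methoxy and hydrogen appear in these comparisons. They also leave open the effect of a longer chain between the two halves of the molecule, taken as a change on its own.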